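This account rests on a few compounds, and the source may have more. Where it says the series, first, only, none or still open, it means among the compounds named here.

Among the compounds with values here, compound 2, `O=C(N1CCC(F)CC1)N1CC(c2nc(-c3cccc(Cl)c3)no2)C1`, shares its core with compound 1, `O=S(=O)(c1ccc(Cl)cc1)N1CC(c2nc(-c3cccc(Cl)c3)no2)C1`, but the two differ in more than one place, so no single measured step links them. In an assay on HEK293 cells for negative allosteric modulation of metabotropic glutamate receptor 5 (Homo sapiens), read by FLIPR (on this read-out higher numbers stand for weaker inhibition and lower numbers for stronger inhibition), compound 2 gives only a limit of the assay, > 10000 nM. Compound 1 gives 170 nM in this assay. Compound 3, `CC1CCN(C(=O)N2CC(c3nc(-c4cccc(Cl)c4)no3)C2)CC1`, differs from compound 2 by methyl in place of fluoro on a saturated ring carbon. Since compound 2 sits at the limit (the limit of > 10000 nM in this assay, at which 1 of the 2 values shown sits), the step of an at least 1.2-fold lower number from compound 2 to compound 3 (0.09 log units; that floor lies within the scatter) is expected to be small, within the scatter or a modest gain. Compound 3 is therefore estimated at 8000 nM, between 2000 nM and 30000 nM.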

Compound 3, half-maximal inhibitory concentration: > 10000 nM
Compound 3: no number, only a limit; the forecaster's own chance of this, stated with the estimate: 65%; at least 1.2-fold (0.09 log units) between middle value and limit.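

Within the data shown here, compound 2 and compound 3 each give only a limit of the assay, not a number, so no step between them can be read. The compounds shown leave open whether methyl in place of fluoro changes inhibition at all.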